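Isopropoxycarbonyl in place of tert-butoxycarbonyl on the piperidine

The source may report more compounds than this note shows. Statements on the series, on what has been measured and on what is new or still open speak of the compounds shown alone.

Compound 2 `Cc1nc(OC2CCN(C(=O)OC(C)(C)C)CC2)c2c(n1)N(c1ccc(S(C)(=O)=O)cc1F)CC2` gives 126 nM in a functional assay on CHO-K1 cells for agonist activity at Glucose-dependent insulinotropic receptor (Homo sapiens), read by a luciferase reporter, with a stated time of 5 h (on this read-out lower numbers stand for an effect already at smaller amounts and higher numbers for an effect only at larger amounts of compound), the higher of the two numbers seen so far; compound 1 `CC(C)OC(=O)N1CCC(Oc2ncnc3c2CCN3c2ccc(S(C)(=O)=O)cc2F)CC1` gives 50.1 nM, a step beyond the scatter, and compound 1 also carries the isopropoxycarbonyl group. Compound 3 `Cc1nc(OC2CCN(C(=O)OC(C)C)CC2)c2c(n1)N(c1ccc(S(C)(=O)=O)cc1F)CC2` differs from compound 2 by hydrogen in place of methyl on a saturated chain carbon bound to an oxygen next to a carbonyl group and two saturated chain carbons. Within the data shown here, no measured pair shows this change alone. Compound 3 is expected to give 80 nM (range 30 nM to 250 nM), an expected step of a 1.6-fold lower number from compound 2 to compound 3 (0.20 log units; within the scatter) toward lower numbers.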

Compound 3, half-maximal effective concentration: 100 nM
Compound 3: the middle estimate sits 1.3-fold (0.10 log units) below what was measured, within the range that was stated.
By their numbers in this assay, from the lowest: compounds 1, 3 and 2 (each within the scatter of the next, the first and the last beyond it).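

In this assay, among these compounds, tert-butoxycarbonyl to isopropoxycarbonyl can now be read alone and gives a 1.3-fold lower number from compound 2 to compound 3 (0.10 log units; within the scatter), so losing this methyl leaves no step that stands out from the scatter. Methyl in place of hydrogen on an aromatic carbon can also be read alone and gives a 2.0-fold higher number from compound 1 to compound 3 (0.30 log units; within the scatter), likewise no step beyond the scatter. Nothing at hand gives a reason for either step. Still open, as far as these compounds go, is whether ethyl or cyclobutyl in place of isopropyl would give a step beyond the scatter. Also open, from the compounds shown here alone, is how an amine or a methoxy group in place of the aromatic methyl would read.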